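Cyclohexyl Ether to Methoxyphenyl Ether in Cytotoxicity

The source may report more compounds than this note shows. Statements on the series, on what has been measured and on what is new or still open speak of the compounds shown alone.

Compound 1 `Cc1ccc(Oc2cccc(CN3CCC(n4cc(C)c(=O)[nH]c4=O)CC3)c2)cc1` in an ADME assay on MRC5 cells (Homo sapiens) for cytotoxicity, read by fluorescence and resazurin assay, with a stated time of 3 days (on this read-out lower numbers stand for stronger inhibition and higher numbers for weaker inhibition), gives only a limit, > 64000 nM.
Compound 2 `Cc1cn(C2CCN(Cc3cccc(OC4CCCCC4)c3)CC2)c(=O)[nH]c1=O` in this assay gives 23600 nM.
Compound 3 `Cc1cn(C2CCN(Cc3cccc(Oc4cccc(C(F)(F)F)c4)c3)CC2)c(=O)[nH]c1=O` in this assay gives 12400 nM.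

Compound 2 holds the highest of the two numbers; its nearest neighbour is compound 3, at a 1.9-fold lower number from compound 2 to compound 3 (0.28 log units; within the scatter); the remaining value, that of compound 1, is a limit (the limit of > 64000 nM in this assay, at which 1 of the 3 values shown sits). Compound 4 `COc1cccc(Oc2cccc(CN3CCC(n4cc(C)c(=O)[nH]c4=O)CC3)c2)c1` differs from compound 2 in one place: 3-methoxyphenyl in place of cyclohexyl on an oxygen on an aromatic ring. Among the measured compounds shown here, two steps bear on this move. The move from 4-methylphenyl to cyclohexyl gave an at least 2.7-fold lower number from compound 1 to compound 2 (0.43 log units; beyond the scatter), while the return to an aromatic group, 3-(trifluoromethyl)phenyl, gave a 1.9-fold lower number from compound 2 to compound 3 (0.28 log units; within the scatter). An aromatic group on that oxygen has thus landed on both sides of compound 2. Compound 4 is therefore expected to stay within the scatter of its neighbour, a 1.3-fold higher number from compound 2 to compound 4 (0.10 log units; within the scatter). The estimate for compound 4 is 30000 nM, with a range from 10000 nM to 80000 nM.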

Compound 4, half-maximal inhibitory concentration: 25300 nM
Estimate against measurement, compound 4: 1.2-fold (0.07 log units) above, and the stated range covers the measured number.
By their numbers in this assay, from the lowest: compounds 3, 2 and 4 (each within the scatter of the next, the first and the last beyond it). At a limit, above all of these: compound 1.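

In this assay, 3-methoxyphenyl and cyclohexyl cannot be told apart on this oxygen: a 1.1-fold higher number from compound 2 to compound 4 (0.03 log units; within the scatter). The group on the aromatic ring does register, with methoxy in place of trifluoromethyl giving a 2.0-fold higher number from compound 3 to compound 4 (0.31 log units; beyond the scatter). The remaining step, an at least 2.5-fold lower number from compound 1 to compound 4 (0.40 log units; beyond the scatter), is only a bound, the value it starts from being a limit: the limit of > 64000 nM in this assay, at which 1 of the 4 values shown sits.

The compounds shown leave open whether an amine or a carboxylic acid on that aromatic ring would shift the number further. They also leave open what a longer chain on the oxygen would do.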